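A Methyl on the Piperidine Ring in Two Settings

The compounds below may be only part of what the source reports. "The series", "measured", "known", "first", "only" and "open" are said of these compounds alone.

Compound 1 `O=C1CN(C2CCCC2)c2nc(Nc3ccc(N4CCCCC4)cn3)ncc2N1` and compound 2 `CC1CCN(c2ccc(Nc3ncc4c(n3)N(C3CCCC3)CC(=O)N4)nc2)CC1` differ in a single place: methyl in place of hydrogen on a saturated ring carbon. In a functional assay on HCT-116 cells (Homo sapiens) for inhibition, read by MTT assay, with a stated time of 48 h (a higher number here means a weaker inhibitor, a lower number a stronger inhibitor), compound 1 gives > 30000 nM, which is a limit of the assay and not a number. Compound 2 likewise returns > 30000 nM, again a limit. Both results rest at the limit of > 30000 nM in this assay, at which 2 of the 3 values shown sit, and so the step that the two limits leave unreadable from compound 1 to compound 2 cannot be read from them.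

Compound 3 `CCN1C(=O)CN(C2CCCC2)c2nc(Nc3ccc(N4CCCCC4)cc3)ncc21` is built on another core; the difference between the two cores is not broken down here. In this assay, going by the values given here, compound 3 gives 5470 nM, the only number among the three measured compounds.

Compound 4 `CCN1C(=O)CN(C2CCCC2)c2nc(Nc3ccc(N4CCC(C)CC4)cc3)ncc21` carries the same alteration relative to compound 3: methyl in place of hydrogen on a saturated ring carbon. The place given for this change matches that of the first pair word for word, so it is the same change, now set on the core of compound 3. Its effect cannot be borrowed from compounds 1 and 2, since the step that the two limits leave unreadable from compound 1 to compound 2 is unreadable from their two limits. Lacking any readable precedent, the plain expectation is that the small addition leaves the measured value near where compound 3 stands. Compound 4 is thus expected to give about 5500 nM, estimated to fall between 2000 nM and 15000 nM. The step this expectation implies is a 1.0-fold higher number from compound 3 to compound 4 (0.00 log units; within the scatter).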

Compound 4, half-maximal inhibitory concentration: 5400 nM
Beside the measured number, compound 4's estimate is 1.0-fold (0.01 log units) above it; low and high end bracket the measured number.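

On the core of compound 3, the change from piperidin-1-yl to 4-methylpiperidin-1-yl gives a 1.0-fold lower number from compound 3 to compound 4 (0.01 log units; within the scatter) in this assay, so on this core the added methyl leaves the read-out where it was. Going by these compounds alone, the same change on the core of compound 1 offers no step to set against this one, because compound 1 and compound 2 both rest at a limit and not at a number: the limit of > 30000 nM in this assay, at which 2 of the 4 values shown sit. The series therefore gives one readable instance of this change, on a single core, and it does not show that the change carries from one core to another, since the result on the core of compound 3 cannot be checked against the core of compound 1.

The compounds shown leave open whether anything other than methyl at the same place, three ring bonds from the ring nitrogen, would move the value on the core of compound 3, for instance an amine, a carboxylic acid or a longer chain such as propyl. They also leave open whether any such group would bring the core of compound 1 to a readable number in this assay.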